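The source may hold more compounds than are shown below. What is called first, only, known or untested is meant among the compounds shown, and "the series" means these compounds.

Measured compounds:
Compound 1, `COc1ccc2nc(C)cc(OCC(=O)Nc3cc(C)ccc3OC)c2c1` — in a toxicity assay on HepG2 cells (Homo sapiens) for inhibition, read by CellTiter-Glo, with a stated time of 48 h (a lower number here means a stronger inhibitor, a higher number a weaker inhibitor), compound 1 gives > 100000 nM, a limit of the assay.
Compound 2, `COc1ccc2nc(C)cc(OCC(=O)Nc3cc(C)c(F)c(C)c3)c2c1` — in this assay compound 2 gives > 100000 nM, a limit of the assay.
Compound 3, `COc1ccc2nc(C)cc(OCC(=O)Nc3cccnc3)c2c1` — in this assay compound 3 gives > 100000 nM, a limit of the assay.

Compound 3 thus stands only at a limit, and the two other values shown are limits as well; all three sit together at the limit of > 100000 nM in this assay, at which 3 of the 3 values shown sit. The measured steps bear on compound 3 only as far as limits allow: a step that the two limits leave unreadable from compound 1 to compound 3 and a step that the two limits leave unreadable from compound 2 to compound 3, and likewise a step that the two limits leave unreadable from compound 1 to compound 2. None of them yields a readable size.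

Compound 4, `COc1ccc2nc(C)cc(OCC(=O)NC3CONC3=O)c2c1`, is not yet measured. It differs from compound 3 in one place: a group of 6 heavy atoms (3 carbon, 1 nitrogen, 2 oxygen; one five-membered non-aromatic ring with 2 hetero atoms) in place of a group of 6 heavy atoms (5 carbon, 1 nitrogen; one six-membered aromatic ring with 1 hetero atom), on an amide-type nitrogen. Within the data shown here, no measured step changes the group on the amide-type nitrogen to anything other than an aromatic ring, so no step of known size carries over to this change. Given that compound 3 and the two other compounds all sit at the limit of > 100000 nM in this assay, at which 3 of the 3 values shown sit, compound 4 is expected to do the same, and a step beyond the scatter is not expected in either direction. For compound 4 the estimate is 150000 nM, with a range from 60000 nM to 400000 nM. The step from compound 3 to compound 4 is therefore expected to be a step that the limit leaves unreadable from compound 3 to compound 4.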

Compound 4, half-maximal inhibitory concentration: > 100000 nM
Compound 4 was reported as a limit; the forecaster's own chance of this, stated with the estimate: 85%; the middle value does not contradict the limit.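

In this assay compound 4 gives > 100000 nM, a limit of the assay. The steps to compound 4 from compound 1, compound 2 and compound 3 therefore cannot be read, and all four compounds sit together: the limit of > 100000 nM in this assay, at which 4 of the 4 values shown sit.

The compounds shown leave open whether any group on the amide-type nitrogen gives a measurable value in this assay.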